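Pyridine amidrazone thiosemicarbazides: removal of a ring methyl

The compounds below may be only part of what the source reports. "The series", "measured", "known", "first", "only" and "open" are said of these compounds alone.

Three members of the series have a number in a functional assay on MCF7 cells (Homo sapiens) for cytotoxicity, read by MTT assay, with a stated time of 72 h, tested at 30 uM; a lower number here means less inhibition of growth, a higher number more inhibition of growth at the concentration tested. Compound 1 `Cc1ccnc(/C(N)=N/NC(=S)N2CCN(c3ccccn3)CC2)c1` gives 63.8%. Compound 2 `Cc1cccc(/C(N)=N/NC(=S)N2CCCC2)n1` gives 40.1%. Compound 3 `N/C(=N\NC(=S)N1CCCC1)c1ccccn1` gives 54.6%.

Compound 2 and compound 3 differ in one place, (hydrogen in place of methyl on an aromatic carbon), and the step is a number 14.5 percentage points higher from compound 2 to compound 3 (beyond the scatter). Compound 1 stands highest of the three, but its gap to compound 3 is within the scatter, so no order between those two can be read; its gap to compound 2 is beyond the scatter. The difference between the core of compound 1 and the core of compound 2 is not broken down here.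

Compound 4 `N/C(=N\NC(=S)N1CCN(c2ccccn2)CC1)c1ccccn1` has not been measured. It differs from compound 1 by hydrogen in place of methyl on an aromatic carbon. This is the same kind of change as that from compound 2 to compound 3, but not the same: there the leaving methyl sat next to the ring nitrogen and meta to a large group, here it sits meta to a large group and opposite the ring nitrogen. Among the measured compounds shown here, the single pair measured so far points upward, and the estimate for compound 4 leans on that pair because a number 14.5 percentage points higher from compound 2 to compound 3 (beyond the scatter) is beyond the scatter, while the different place around the methyl and the high starting value of compound 1 argue for a smaller move. The expected step is a number 7.2 percentage points higher from compound 1 to compound 4 (within the scatter). Compound 4 is therefore estimated at 71%, with a likely range from 57% to 84%.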

Compound 4, percent growth inhibition at one concentration: 65.3%
Compound 4: the middle estimate sits 5.7 percentage points above what was measured; the measured number falls inside the stated range.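

In this assay, taking the methyl off the core of compound 1 gives a number 1.5 percentage points higher from compound 1 to compound 4 (within the scatter), so on this core the change to 4-methylpyridin-2-yl to pyridin-2-yl cannot be told apart from no effect at all. The two pairs that carry this change can be set side by side, and their steps cannot be separated: the same change on two cores in this assay, a number 14.5 percentage points higher (beyond the scatter) from compound 2 to compound 3 and a number 1.5 percentage points higher (within the scatter) from compound 1 to compound 4, 13 percentage points apart, within the scatter of two such steps. Among the compounds shown here, this shows that the small step on the core of compound 1 does not contradict the larger step seen on the other core, but it does not show that the change carries over at a fixed size, and with only two pairs, which differ both in the place of the methyl and in the rest of the core, neither difference can be weighed on its own.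

Still open, as far as these compounds go, is whether the methyl, set opposite the ring nitrogen on the core of compound 3, would give a step like that of compound 1 to compound 4 or like that of compound 2 to compound 3. The compounds shown also leave open what a group other than methyl at that place on the ring, such as a methoxy group, a chlorine atom or an amine, would do to the number on either core.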